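The source may hold more compounds than are shown below. What is called first, only, known or untested is meant among the compounds shown, and "the series" means these compounds.

Compound 1, `O=S(=O)(Nc1ccc(-c2nc3ccccc3o2)cc1)c1ccccc1Cl`: in an assay on cells for inhibition of HSP60/HSP10 (Homo sapiens), with a stated time of 60 min (on this read-out higher numbers stand for weaker inhibition and lower numbers for stronger inhibition), compound 1 gives > 100000 nM, which is a limit of the assay rather than a measured number.
Compound 2, `COc1cccc(S(=O)(=O)Nc2ccc3oc(-c4ccccc4)nc3c2)c1`: in this assay compound 2 gives > 100000 nM, again a limit.
Compound 3, `O=S(=O)(Nc1ccc2oc(-c3ccccc3)nc2c1)c1ccccc1F`: in this assay compound 3 gives > 100000 nM, again a limit.

Compound 1 therefore stands at the limit of > 100000 nM in this assay, at which 3 of the 3 values shown sit. Its true inhibition is known only to be weaker than that ceiling.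

Compound 4, `COc1ccc(S(=O)(=O)Nc2ccc(-c3nc4ccccc4o3)cc2)cc1`, is still to be measured. It differs from compound 1 in one place: 4-methoxyphenyl in place of 2-chlorophenyl on a sulfonyl sulfur.

Within the data shown here, only one measured pair differs in a single place, the step that the two limits leave unreadable from compound 2 to compound 3, and it too runs between two limits, so its size cannot be read. Among the measured compounds shown here, no measured step therefore shows whether exchanging the ring on the sulfonyl sulfur moves the result beyond the scatter, and no direction can be taken from the data.

The expectation for compound 4 is that it also reaches only the limit, an estimated step that the limit leaves unreadable from compound 1 to compound 4. Compound 4 is estimated at 150000 nM, with a range from 30000 nM to 1000000 nM.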

Compound 4, half-maximal inhibitory concentration: > 100000 nM
Compound 4 ended at the assay's limit (the forecaster's own chance of this, stated with the estimate: 85%); the middle value lies beyond the limit too.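

No step can be read from compound 1 to compound 4, because both stand at a limit rather than a measured number: the limit of > 100000 nM in this assay, at which 4 of the 4 values shown sit.

The compounds shown leave open whether any group on the sulfonyl sulfur, or any change to the shared core, gives inhibition strong enough to yield a measured number.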